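Swapping a chlorophenyl for a fluorophenyl on an inactive core

This account rests on a few compounds, and the source may have more. Where it says the series, first, only, none or still open, it means among the compounds named here.

Of the compounds shown here, two sharing one core have been tested in a functional assay on A549 cells (Homo sapiens) for antiproliferative activity, read by MTT assay, with a stated time of 72 h; on this read-out higher numbers stand for weaker inhibition and lower numbers for stronger inhibition. Compound 1 (`COc1cc(-n2ncnc2-c2ccc(OC(C)C)cc2)cc(OC)c1OC`) gives > 10000 nM, which is a limit of the assay and not a number. Compound 2 (`COc1cc(-n2ncnc2-c2cccc(Cl)c2)cc(OC)c1OC`) gives > 10000 nM, again a limit and not a number. Within the data shown here, compound 2 therefore stands at the limit of > 10000 nM in this assay, at which 2 of the 2 values shown sit, and no measured step between compounds exists.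

Compound 3 (`COc1cc(-n2ncnc2-c2ccc(F)cc2)cc(OC)c1OC`) keeps the shared core but carries 4-fluorophenyl in place of 3-chlorophenyl on an aromatic carbon. With only limits to go on, no step beyond the scatter is expected in this assay. This expectation rests on compound 2, whose limit is > 10000 nM. The expected step that the limit leaves unreadable from compound 2 to compound 3 is an estimate only. For compound 3 the estimated value is 12000 nM, with an expected range from 3000 nM to 30000 nM.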

Compound 3, half-maximal inhibitory concentration: > 10000 nM
Compound 3: a limit, no number (the forecaster's own chance of this, stated with the estimate: 75%); the middle value lies beyond the limit too.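

In this assay compound 3 gives > 10000 nM, a limit and not a number. Its steps from compound 1 and from compound 2 cannot be read, since all three compounds sit at a limit: the limit of > 10000 nM in this assay, at which 3 of the 3 values shown sit.

Left open is whether any change on the shared core gives a readable value in this assay.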